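Replacing the formyl group of compound 2

The compounds below may be only part of what the source reports. "The series", "measured", "known", "first", "only" and "open" are said of these compounds alone.

- compound 1 `C=C[C@](C)(CCCC(C)C)CCc1ccc(O)cc1`: > 26000 nM
- compound 2 `COc1ccc(/C=C/[C@@](C)(/C=C/c2ccc(O)c(C=O)c2)CCC=C(C)C)cc1`: 13000 nM

Both compounds were read in a functional assay on Raji cells (Homo sapiens) for cytotoxicity, with a stated time of 72 h; on this read-out higher numbers stand for an effect only at larger amounts of compound and lower numbers for an effect already at smaller amounts. Compound 1 gives > 26000 nM, which is a limit of the assay and not a number. Among the measured compounds shown here, compound 2, at 13000 nM, holds the only true number so far, and the series offers no measured step between related compounds.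

Compound 3 `COc1ccc(/C=C/[C@@](C)(/C=C/c2ccc(O)c(/C=C/C(=O)OC(C)(C)C)c2)CCC=C(C)C)cc1` has 2-(tert-butoxycarbonyl)ethenyl in place of formyl on an aromatic carbon, ortho to a hydroxy group: 2-(tert-butoxycarbonyl)ethenyl in place of formyl on an aromatic carbon. The rest of the structure is shared with compound 2.

For the measured compounds named here, with no measured step as a guide, little movement is expected in this assay, most likely none beyond the scatter. The expected change is a 1.2-fold lower number from compound 2 to compound 3 (0.07 log units; within the scatter). For compound 3 the estimated value is 11000 nM, with an expected range of 4000 nM to 26000 nM.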

Compound 3, half-maximal effective concentration: > 26000 nM
Compound 3 gave a limit, no number; the forecaster's own chance of this, stated with the estimate: 25%; at least 2.3-fold (0.37 log units) between middle value and limit.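

On an aromatic carbon ortho to a hydroxy group, 2-(tert-butoxycarbonyl)ethenyl in place of formyl gives an at least 2.0-fold higher number from compound 2 to compound 3 (0.30 log units; that floor lies within the scatter) in this assay. Among the compounds shown here, this is the first measured step, and it shows that this position tolerates no gain from the larger group: the change does not bring the number down. Compound 3 sits at a limit, so the step has a floor but no true size, and a real loss at this position is neither shown nor excluded: the limit of > 26000 nM in this assay, at which 2 of the 3 values shown sit.

Going by these compounds, whether the formyl group itself contributes to the value of compound 2 remains open. So does how a hydroxymethyl group, a carboxylic acid or an amine would read at this position, and whether a methyl ester on the same ethenyl chain would return a true number.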